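Swapping a methoxyphenyl for a fluorostyryl in a cytotoxicity series

The source may hold more compounds than are shown below. What is called first, only, known or untested is meant among the compounds shown, and "the series" means these compounds.

Compound 1 `CC(=O)c1cc(-c2ccccc2)cc2cc(-c3ccccc3)[nH]c12` gives only a limit of the assay, > 100000 nM, in a functional assay on HeLa cells (Homo sapiens) for cytotoxicity, read by MTT assay, with a stated time of 2 days; on this read-out lower numbers stand for higher toxicity in this test and higher numbers for lower toxicity in this test.
Compound 2 `COc1ccc(-c2cc(C(C)=O)c3[nH]c(-c4ccccc4)cc3c2)cc1` gives 15500 nM in this assay.

For the measured compounds named here, compound 2 holds the only actual number in this assay; the other value shown is a limit. Going by the values given here, the one measured step, an at least 6.4-fold lower number from compound 1 to compound 2 (0.80 log units; beyond the scatter), rests on that limit, as told by the limit of > 100000 nM in this assay, at which 1 of the 2 values shown sits, so its true size is not known beyond the bound.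

Compound 3 `CC(=O)c1cc(/C=C/c2ccc(F)cc2)cc2cc(-c3ccccc3)[nH]c12` is not yet measured. It differs from compound 2 by 2-(4-fluorophenyl)ethenyl in place of 4-methoxyphenyl on an aromatic carbon. No measured step covers this change: the only step shown concerns adding a methoxy, whereas here the whole 4-methoxyphenyl leaves and a 2-(4-fluorophenyl)ethenyl enters in its place. Among the compounds with values here, the pair compound 1 and compound 2 shows only that the methoxy-bearing compound gave a number while the unsubstituted one gave a limit. Since the methoxy now departs, the expectation leans toward a number near compound 2 or somewhat higher, with wide uncertainty. For compound 3 in this assay the estimate is 20000 nM, between 5000 nM and 100000 nM, which would mean a step of a 1.3-fold higher number from compound 2 to compound 3 (0.11 log units; within the scatter) expected from the measured compound to the new one.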

Compound 3, concentration lethal to 50% of the cells: 9260 nM
Beside the measured number, compound 3's estimate is 2.2-fold (0.33 log units) above it, and the stated range covers the measured number.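

In this assay, the step of a 1.7-fold lower number from compound 2 to compound 3 (0.22 log units; within the scatter) shows that this position, meta to an acetyl group, tolerates a real change of substituent: 2-(4-fluorophenyl)ethenyl can replace 4-methoxyphenyl without the two numbers separating. Compound 3 carries no methoxy yet still gives a number, so a methoxy is not required for a measurable result in this series. The step of an at least 10-fold lower number from compound 1 to compound 3 (1.03 log units; beyond the scatter) adds a second substituted group that gives a number where the plain phenyl of compound 1 gives only a limit, although the true size of this step stays unknown: the limit of > 100000 nM in this assay, at which 1 of the 3 values shown sits.

The compounds shown do not separate the contributions of the fluorine and the double bond, since both arrive together in 2-(4-fluorophenyl)ethenyl, and a plain 4-fluorophenyl or an unsubstituted styryl group would be needed to tell them apart. Going by these compounds, whether an amine or a carboxylic acid on the outer ring at this position would keep a number of this order also remains open.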